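Isopropyl for methyl on the amide nitrogen of compound 2

The source may hold more compounds than are shown below. What is called first, only, known or untested is meant among the compounds shown, and "the series" means these compounds.

Three compounds share a common core and were tested in a functional assay on the whole organism with Mus musculus as the target, at a dose of 100 mg/kg by the intraperitoneal route; on this read-out higher numbers stand for more inhibition at the one dose given (going by the name of the read-out) and lower numbers for less inhibition. Compound 1 `CNC(=O)/C=C1\CCc2cc(F)c(F)cc21` gives 100% in this assay. Compound 2 `CNC(=O)/C=C1\CCc2c(F)cc(F)cc21` gives 100%, level with compound 1 at the digits reported, and together these two hold the highest numbers of the three. Compound 3 `O=C(/C=C1\CCc2ccc(Cl)cc21)NC1CC1` differs from compound 2 in more than one place. In this assay compound 3 gives 50%. Within the data shown here, that number is lower than the one of compound 2, and the gap lies beyond the scatter of repeated measurements.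

Compound 4 `CC(C)NC(=O)/C=C1\CCc2c(F)cc(F)cc21` has not yet been measured. It differs from compound 2 in one place: isopropyl in place of methyl on an amide-type nitrogen. Among the measured compounds shown here, no step between measured compounds isolates this change, so its size in this assay is open. Compound 3, which carries a larger group on the amide nitrogen among its differences, gives a lower number, but that comparison does not separate the amide change from the others. Compound 4 is expected to give 80% in this assay, between 40% and 100%. The expected step of a number 20 percentage points lower from compound 2 to compound 4 (beyond the scatter) is estimated as a modest drop that may not exceed the scatter.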

Compound 4, a percentage reported as inhibition, in the whole organism at one dose (the size of the read-out at that dose, not a potency): 100%
Compound 4: middle estimate off by 20 percentage points, on the low side, and the stated range covers the measured number.
By their numbers in this assay, from the lowest: compound 3; then compounds 1, 2 and 4 (each within the scatter of the next).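

Isopropyl in place of methyl on the amide-type nitrogen gives, in this assay, no change at the digits printed from compound 2 to compound 4 (within the scatter), and this is the first step that isolates this position. It shows that at the one dose given this nitrogen accepts the branched group of 3 heavy atoms as well as methyl, though with both compounds at the full number the read-out, which is not a potency, could hide a difference that a lower dose might reveal. No measurement is at hand that bears on the reason for this result.

As far as these compounds go, how far this position goes remains open: a tert-butyl group, a benzyl group or a chain ending in an amine on this nitrogen could behave differently. From the compounds shown here alone, the plain primary amide, with only hydrogen there, also remains open.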